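Shortening the alkoxy chain on the shared core

This account rests on a few compounds, and the source may have more. Where it says the series, first, only, none or still open, it means among the compounds named here.

Of the compounds shown here, three on the shared core have been measured in a functional assay on A2780/DX3 cells (Homo sapiens) for antiproliferative activity, read by MTT assay, with a stated time of 3 days; on this read-out higher numbers stand for weaker inhibition and lower numbers for stronger inhibition. Compound 1 `CC1=CSC(O)(c2cccc([N+](=O)[O-])c2)c2noc(=O)n21` gives 129000 nM. Compound 2 `CCCCCOC1(c2ccc(Cl)cc2)SC=C(C)n2c1noc2=O` gives > 100000 nM in this assay, which is a limit of the assay and not a number. Compound 3 `CC/C=C\COC1(c2ccc(Cl)cc2)SC=C(C)n2c1noc2=O` gives 103000 nM in this assay; compound 3 and compound 1 sit within the scatter of each other. Among the compounds with values here, the only step between measured compounds that differ in one place is a step that the limit leaves unreadable from compound 2 to compound 3, which cannot be read as a size since compound 2 sits at the limit of > 100000 nM in this assay, at which 1 of the 3 values shown sits.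

Compound 4 `COC1(c2ccc(Cl)cc2)SC=C(C)n2c1noc2=O` differs from compound 3 by hydrogen in place of but-1-en-1-yl on a saturated chain carbon bound to an oxygen on a saturated carbon. Within the data shown here, no measured step changes the same position in a readable way, so the only guidance is that every number shown sits far up the scale and that the one chain change, from compound 2 to compound 3, left no readable step. The expectation for compound 4 in this assay is therefore no step beyond the scatter, that is a 1.5-fold higher number from compound 3 to compound 4 (0.16 log units; within the scatter). Compound 4 is estimated at 150000 nM in this assay, with a range from 60000 nM to 400000 nM, and a real chance that only a limit is reported.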

Compound 4, half-maximal inhibitory concentration: 113000 nM
The estimate for compound 4 lay 1.3-fold (0.12 log units) above the measured number; the range from low to high includes it.
By their numbers in this assay, from the lowest: compounds 3, 4 and 1 (each within the scatter of the next).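

In this assay, hydrogen in place of but-1-en-1-yl on a saturated chain carbon bound to an oxygen on a saturated carbon, which turns (pent-2-en-1-yl)oxy into methoxy, gives a 1.1-fold higher number from compound 3 to compound 4 (0.04 log units; within the scatter). Within the data shown here, this is the first readable step at this position, and it shows that removing a chain of 4 carbon atoms does not separate the two compounds on this read-out, with both numbers still far up the scale. The steps that start from compound 2 cannot be read, as compound 2 gives a limit of the assay and not a number: the limit of > 100000 nM in this assay, at which 1 of the 4 values shown sits.

Going by these compounds, what remains open is whether any group at this position can bring the number down the scale at all, and an amine or a carboxylic acid at the end of the chain would put that to the test. Among these compounds, whether the saturated butyl and the unsaturated but-1-en-1-yl differ at this position also stays unanswered, since the only comparison between them runs through the limit.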